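This account rests on a few compounds, and the source may have more. Where it says the series, first, only, none or still open, it means among the compounds named here.

Compound 1 `Cc1ccc(S(=O)(=O)N[C@H]2CC[C@@H](F)[C@@H]2C/C=C\CCCC(=O)O)cc1` is the reference point of the series. Among the measured compounds shown here, in a functional assay on a cell-free system (plasma) for inhibition of thromboxane A2 receptor (Homo sapiens), read by turbidimetry (a lower number here means a stronger inhibitor, a higher number a weaker inhibitor), compound 1 gives 260 nM, the lowest of the three numbers so far. Compound 2 `O=C(O)CCCCCC[C@H]1[C@H](F)CC[C@@H]1NS(=O)(=O)c1ccc(F)cc1` gives 2400 nM in this assay, and compound 3 `O=C(O)CCC/C=C\CC1=CCC[C@@H]1NS(=O)(=O)c1ccccc1` gives 2300 nM; both gaps to compound 1 lie beyond the scatter, while the numbers for compound 2 and compound 3 sit close to each other. Compound 4 `O=C(O)CCC/C=C\C[C@H]1[C@H](F)CC[C@@H]1NS(=O)(=O)c1ccccc1` has not yet been measured in this assay. It differs from compound 1 in one place: hydrogen in place of methyl on an aromatic carbon. For the measured compounds named here, no measured pair isolates this change, so the size of the step rests on the structural change alone. Loss of the methyl from the six-membered aromatic ring of carbon only is expected to cost little, with the number drifting upward rather than downward. The expected step is a 1.9-fold higher number from compound 1 to compound 4 (0.28 log units; within the scatter), modest and toward a weaker inhibitor, likely near the edge of the scatter. For compound 4 the estimate in this assay is 500 nM, with a range of 150 nM to 1600 nM.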

Compound 4, half-maximal inhibitory concentration: 1100 nM
For compound 4 the middle estimate is 2.2-fold (0.34 log units) below the measured one; the range from low to high includes it.
By their numbers in this assay, from the lowest: compound 1; then compound 4; then compounds 3 and 2 (each within the scatter of the next).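

In this assay, among the compounds shown here, the change from 4-methylphenyl to phenyl gives the first step that isolates one place: a 4.2-fold higher number from compound 1 to compound 4 (0.63 log units; beyond the scatter). The methyl on the aromatic carbon, para to a large group, therefore contributes measurably to the inhibition shown by compound 1, since nothing else differs within this pair. No available data account for the size of this step.

Whether this contribution is specific to methyl stays open, as no other group, such as ethyl, methoxy or chlorine, is shown at this place on the otherwise unchanged structure. For the compounds shown here, with only one pair defining the step, it is also unknown whether removing the methyl would cost as much on a different chain or core.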